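This account rests on a few compounds, and the source may have more. Where it says the series, first, only, none or still open, it means among the compounds named here.

Series data in an assay on isolated protein for activation of cGMP-dependent protein kinase 1 (Homo sapiens), read by ADP-Glo, with stated times of 120 min and 40 min; a lower number here means that less compound is needed, a higher number that more compound is needed for the effect:

Compound 1 `Clc1cc(Cl)cc(CO[C@H]2CCCN(Cc3ccncc3)[C@H]2c2ccccc2)c1` gives > 200000 nM, a limit of the assay.
Compound 2 `Clc1cc(Cl)cc(CO[C@H]2CCCN(Cc3ccccn3)[C@H]2c2ccccc2)c1` gives > 200000 nM, a limit of the assay.
Compound 3 `CN1CCC[C@H](OCc2cc(Cl)cc(Cl)c2)[C@@H]1c1ccccc1` gives > 200000 nM, a limit of the assay.

Compound 3 therefore stands nowhere in particular on the numbers: it sits at the same limit as both other compounds, as the limit of > 200000 nM in this assay, at which 3 of the 3 values shown sit, records, so no ranking within the three is possible.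

The next compound, compound 4 `Cn1cc(CN2CCC[C@H](OCc3cc(Cl)cc(Cl)c3)[C@@H]2c2ccccc2)cn1`, differs from compound 3 by 1-methyl-1H-pyrazol-4-yl in place of hydrogen on a saturated chain carbon bound to an amine nitrogen in a ring.

The measured steps that bear on this change are those that add or remove an aryl group at the same place: a step that the two limits leave unreadable from compound 1 to compound 3 and a step that the two limits leave unreadable from compound 2 to compound 3 both run from an aryl-bearing compound to the unsubstituted methyl, and a step that the two limits leave unreadable from compound 1 to compound 2 exchanges one such aryl for another. All three are unreadable, since every value is a limit. There is thus no measured sign that an aromatic ring at this position gives a reading in this assay in either direction.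

The expectation for compound 4 is accordingly that it also stays at the limit, with an estimated value of 200000 nM and a range from 100000 nM to 1000000 nM. This estimate means a step of a number no higher from compound 3 to compound 4 (the limit leaves the size open), expected to be none beyond the scatter.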

Compound 4, half-maximal effective concentration: 110000 nM
For compound 4 the middle estimate is 1.8-fold (0.26 log units) above the measured one, within the range that was stated.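

In this assay, 1-methyl-1H-pyrazol-4-yl on a saturated chain carbon bound to an amine nitrogen in a ring gives the only reading of the series that is a number and not a limit: the limit of > 200000 nM in this assay, at which 3 of the 4 values shown sit.

Set against hydrogen, the change reads as an at least 1.8-fold lower number from compound 3 to compound 4 (0.25 log units; that floor lies within the scatter); against pyridin-2-yl, as an at least 1.8-fold lower number from compound 2 to compound 4 (0.25 log units; that floor lies within the scatter); and against pyridin-4-yl, as an at least 1.8-fold lower number from compound 1 to compound 4 (0.25 log units; that floor lies within the scatter). These are floors, so this place can now carry a measurable reading, but no step is shown to lie beyond the scatter.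

Going by these compounds, the true size of each step stays open, as the other three compounds give only limits. Also open, on these data alone, is whether the pyrazole ring itself or its methyl matters, and how an amine, a carboxylic acid or a longer chain would read at this place.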